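A Smaller Amine Ring on the Shared Core

The compounds below may be only part of what the source reports. "The series", "measured", "known", "first", "only" and "open" are said of these compounds alone.

Compound 1 `CCN1CCN(c2cc(C)c3cc(NC(=O)c4cccnc4)ccc3n2)CC1`: 26600 nM
Compound 2 `Cc1cc(N2CCN(C(C)C)CC2)nc2ccc(NC(=O)c3ccc(Cl)c(Cl)c3)cc12`: 1710 nM
Compound 3 `CCN1CCN(c2cc(C)c3cc(NC(=O)c4ccco4)ccc3n2)CC1`: 41200 nM

In a functional assay on MCF7 cells (Homo sapiens) for antiproliferative activity, read by MTT assay, with a stated time of 72 h (on this read-out higher numbers stand for weaker inhibition and lower numbers for stronger inhibition), compound 2 gives 1710 nM, the lowest of the three numbers. Compound 1 gives 26600 nM and compound 3 gives 41200 nM; both gaps to compound 2 lie beyond the scatter, so compound 2 is the strongest inhibitor measured here. Among the measured compounds shown here, the one measured step among them, a 1.5-fold higher number from compound 1 to compound 3 (0.19 log units; within the scatter), changes only the group on the carbonyl carbon and stays within the scatter.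

Compound 4 `Cc1cc(N2CCCC2)nc2ccc(NC(=O)c3ccc(Cl)c(Cl)c3)cc12` differs from compound 2 in a single place: pyrrolidin-1-yl in place of 4-isopropylpiperazin-1-yl on an aromatic carbon. The amine side of the shared core has not been varied in any measured pair, so the step from compound 1 to compound 3 does not bear on this change; it tells only that the amide side tolerates a swap without a clear shift. The chloro-bearing amide that sets compound 2 apart is kept intact in compound 4.

For the measured compounds named here, with no direct precedent, a moderate step toward a higher number is expected for compound 4: a 2.0-fold higher number from compound 2 to compound 4 (0.31 log units; beyond the scatter). Compound 4 is therefore estimated at 3500 nM, with a plausible range from 800 nM to 15000 nM.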

Compound 4, half-maximal inhibitory concentration: 26300 nM
The estimate for compound 4 lay 7.5-fold (0.88 log units) below the measured number; the whole stated range lies below it.
By their numbers in this assay, from the lowest: compound 2; then compounds 4, 1 and 3 (each within the scatter of the next).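

Pyrrolidin-1-yl in place of 4-isopropylpiperazin-1-yl gives a 15-fold higher number from compound 2 to compound 4 (1.19 log units; beyond the scatter) in this assay and is the first measured step on the amine side of the shared core. The chloro-bearing amide stays the same across this step, so that amide alone does not secure the low number of compound 2, and the group on this aromatic carbon next to the ring nitrogen has a large effect on the result. This single change shrinks the ring and also removes the second ring nitrogen and the isopropyl group, and nothing available explains why the number rises.

The compounds shown leave open which of these differences carries the step: piperidin-1-yl would keep the six-membered ring without the second nitrogen, while piperazin-1-yl would keep both ring nitrogens without the isopropyl group. Going by these compounds, it also remains open whether a step of this size would recur with another amide, such as the furan-2-yl amide of compound 3, on the same core.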